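A Methyl Added to the Aryl Ring of Compound 2

The source may report more compounds than this note shows. Statements on the series, on what has been measured and on what is new or still open speak of the compounds shown alone.

Two ureas have been measured in an assay on CHO cells for displacement of a labelled ligand from histamine receptor H3 (Macaca mulatta), read by scintillation counting, with a stated time of 1 h; on this read-out lower numbers stand for stronger inhibition and higher numbers for weaker inhibition. Compound 1 `Cc1c(Cl)cc(NC(=O)Nc2ccc(OCCCN3CCCCC3)cc2)cc1Cl` carries a piperidine on a propoxy chain and gives 18.2 nM. Compound 2 `CC1CCCN1C1CCN(c2ccc(NC(=O)Nc3ccc(Oc4ccccc4)cc3)cc2)C1` instead bears a phenoxy group at one end and a 3-(2-methylpyrrolidin-1-yl)pyrrolidin-1-yl group on the opposite aryl ring, and in this assay compound 2 gives 46.8 nM. Among the two numbers, compound 2 has the higher one, and its gap to compound 1 is beyond the usual scatter of repeated measurements.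

Compound 3 `Cc1cc(NC(=O)Nc2ccc(Oc3ccccc3)cc2)ccc1N1CCC(N2CCCC2C)C1` keeps the whole framework of compound 2 and differs only in one place: methyl in place of hydrogen on an aromatic carbon. For the measured compounds named here, nothing in the measured pair speaks to this particular change, since no step between the two measured compounds is comparable to it. A single methyl on an aromatic carbon is a small alteration, and the expected step from compound 2 to compound 3 in this assay is a 1.2-fold lower number from compound 2 to compound 3 (0.07 log units; within the scatter), that is, none beyond the scatter. Compound 3 is therefore estimated at 40 nM, with a plausible range from 12 nM to 130 nM.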

Compound 3, inhibition constant: 115 nM
Compound 3: middle estimate off by 2.9-fold (0.46 log units), on the low side; low and high end bracket the measured number.
By their numbers in this assay, from the lowest: compound 1; then compound 2; then compound 3.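

In this assay, methyl in place of hydrogen on this aromatic carbon, ortho to the 3-(2-methylpyrrolidin-1-yl)pyrrolidin-1-yl group, brings a 2.5-fold higher number from compound 2 to compound 3 (0.39 log units; beyond the scatter) in a step that is modest yet beyond the scatter. This is the first change in one place among the compounds shown, and it establishes that this carbon is not indifferent to substitution: one added carbon, with no ring, no hydrogen-bond donor or acceptor and no net charge, is enough to give weaker inhibition here. Nothing available bears on what lies behind this rise, so the step stands as an observation only.

Going by these compounds, whether the rise belongs to methyl alone or would also follow a fluorine atom, a methoxy group or a hydroxyl group on this same carbon remains open. Also open, on these data alone, is whether methyl on the ring carrying the phenoxy group would move the number in the same direction, and whether the same change would act alike on the core of compound 1, with its piperidine on a propoxy chain.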